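Adding an Ethoxycarbonyl to the Pyridyl Thioether

A few compounds are considered here, and "the series" means these few. Any claim that something is new, unique, unknown or untested is made for them only; others in the source may bear on it.

Measured so far:
Compound 1 `COc1nc2ccc(CSc3ccc(Cl)c(Cl)c3)cc2nc1OC`: 75000 nM
Compound 2 `COc1nc2ccc(CSc3ccccn3)cc2nc1OC`: > 100000 nM
Compound 3 `CCOC(=O)CC[C@H](NC(=O)c1ccccc1SCc1ccc2nc(OC)c(OC)nc2c1)C(=O)OCC`: > 100000 nM

In an ADME assay on Vero 76 cells (Chlorocebus sabaeus) for cytotoxicity, read by MTT assay, with a stated time of 96 h (a lower number here means that less compound is tolerated, a higher number that more compound is tolerated), compound 2 gives > 100000 nM, which is a limit of the assay and not a number. Compound 3 also sits at a limit in this assay, > 100000 nM. So compound 2 stands at the upper edge of what this assay reports, and it shares that edge with compound 3, as the limit of > 100000 nM in this assay, at which 2 of the 3 values shown sit, shows. Within the data shown here, the only step measured in this set is an at least 1.3-fold higher number from compound 1 to compound 2 (0.12 log units; that floor lies within the scatter), a change at the group on the sulfur.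

Compound 4 `CCOC(=O)c1ccc(SCc2ccc3nc(OC)c(OC)nc3c2)nc1` differs from compound 2 by ethoxycarbonyl in place of hydrogen on an aromatic carbon. Among the measured compounds shown here, no measured step touches that ring position, so the one step that bears on it is the swap on the sulfur, which gave at most a small shift. The expected step is therefore a number no higher from compound 2 to compound 4 (the limit leaves the size open), meaning no change beyond the scatter. Compound 4 is expected to give 100000 nM, within 50000 nM to 300000 nM, most likely again as a limit.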

Compound 4, half-maximal cytotoxic concentration: > 100000 nM
Compound 4 was reported as a limit; the forecaster's own chance of this, stated with the estimate: 60%; the middle value sits exactly at the limit.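

Compound 2 and compound 4 both sit at a limit in this assay, so no step between them can be read: the limit of > 100000 nM in this assay, at which 3 of the 4 values shown sit.

The compounds shown leave open how much of either compound is tolerated, and so whether ethoxycarbonyl in place of hydrogen on an aromatic carbon changes it at all.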